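Bromo to trifluoromethyl swap tested against a second core

A few compounds are considered here, and "the series" means these few. Any claim that something is new, unique, unknown or untested is made for them only; others in the source may bear on it.

In an assay on isolated protein for inhibition of Amine oxidase [flavin-containing] B (Homo sapiens) (a lower number here means a stronger inhibitor, a higher number a weaker inhibitor), compound 1 `C#CCNC1CCc2c(SCCc3cccc(C(F)(F)F)c3)cccc21` gives 3720 nM and compound 2 `C#CCNC1CCc2c(SCCc3cccc(Br)c3)cccc21` gives 30500 nM. The step of an 8.2-fold lower number from compound 2 to compound 1 (0.91 log units; beyond the scatter) is trifluoromethyl in place of bromo on an aromatic carbon. Compound 3 `C#CCNC1CCc2c(SCc3cccc(Br)c3)cccc21` reaches only a limit of this assay, > 100000 nM. That value sits at the limit of > 100000 nM in this assay, at which 1 of the 3 values shown sits. How the core of compound 3 differs from the core of compound 2 is not broken down here. Compound 4 `C#CCNC1CCc2c(SCc3cccc(C(F)(F)F)c3)cccc21` is not yet measured; it differs from compound 3 by trifluoromethyl in place of bromo on an aromatic carbon, the same change made from compound 2 to compound 1. Compound 4 is expected to reach 40000 nM, because an 8.2-fold lower number from compound 2 to compound 1 (0.91 log units; beyond the scatter) gave a gain of comparable size and the estimate applies it to the limit value, so the estimated step is an at least 2.5-fold lower number from compound 3 to compound 4 (0.39 log units; beyond the scatter). The expected range for compound 4 runs from 10000 nM to 150000 nM, and a limit rather than a number remains possible.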

Compound 4, half-maximal inhibitory concentration: 4.7 nM
Compound 4: the middle estimate sits 8500-fold (3.93 log units) above what was measured; the measured number lies below the stated range.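

In this assay, trifluoromethyl in place of bromo again gives a lower number, an at least 21000-fold lower number from compound 3 to compound 4 (4.32 log units; beyond the scatter), so the direction of the change carries to the second core. The size of the change does not carry: the same change on two cores in this assay, an 8.2-fold lower number (0.91 log units; beyond the scatter) from compound 2 to compound 1 and an at least 21000-fold lower number (4.32 log units; beyond the scatter) from compound 3 to compound 4, at least 2500-fold (3.41 log units) apart, beyond the scatter of two such steps. Compound 3 gives > 100000 nM, a limit and not a number, so the new step is known only as a minimum, and two cores give no general rule for the series: the limit of > 100000 nM in this assay, at which 1 of the 4 values shown sits.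

From the compounds shown here alone, what separates the two cores in their response to this change remains open. Also open, going by these compounds, is how chloro, a nitrile or a carboxylic acid in the same place would behave on either core.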